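A few compounds are considered here, and "the series" means these few. Any claim that something is new, unique, unknown or untested is made for them only; others in the source may bear on it.

Working notes on the series.

Two compounds on the shared core carry a value in an assay on isolated protein for inhibition of G protein-coupled receptor kinase 6 (Homo sapiens), read by scintillation counting, radiometric assay and 33P incorporation, with a stated time of 80 min, in the presence of a further agent that is not named here; on this read-out higher numbers stand for weaker inhibition and lower numbers for stronger inhibition. Compound 1 `CCc1cc(Nc2nc(N[C@@H](C)c3ccc(F)cc3)nc3ccccc23)n[nH]1` gives 120 nM in this assay. Compound 2 `CCc1cc(Nc2nc(N[C@@H](C)c3ccc(C)cc3)nc3cccc(F)c23)n[nH]1` gives 27 nM in this assay and stands at the lower of the two numbers; the nearest number, that of compound 1, lies beyond the scatter above it. Among the measured compounds shown here, the two compounds differ in more than one place, so no single step between them can be read.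

Compound 3 `CCc1cc(Nc2nc(N[C@@H](C)c3ccc(F)cc3)nc3cccc(F)c23)n[nH]1` is not yet measured. It differs from compound 2 by fluoro in place of methyl on an aromatic carbon — fluoro in place of methyl on an aromatic carbon, para to a large group, read one bond further out as 1-(4-methylphenyl)ethyl to 1-(4-fluorophenyl)ethyl. For the measured compounds named here, the 4-fluorophenyl side chain is the one carried by compound 1, whose value in this assay is 120 nM; the fluoro on the core is the one carried by compound 2, with 27 nM. Which of the two changes accounts for the gap between them is not known.

A small step is expected from compound 2 to compound 3 in this assay, a 1.7-fold higher number from compound 2 to compound 3 (0.22 log units; within the scatter), direction uncertain, probably within the scatter. Compound 3 is estimated at 45 nM, with a range from 15 nM to 150 nM in this assay.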

Compound 3, half-maximal inhibitory concentration: 41 nM
Compound 3: middle estimate off by 1.1-fold (0.04 log units), on the high side, and the stated range covers the measured number.
By their numbers in this assay, from the lowest: compounds 2 and 3 (each within the scatter of the next); then compound 1.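

In this assay, the side-chain change from 4-methylphenyl to 4-fluorophenyl, with fluoro in place of methyl on an aromatic carbon para to a large group, gives a 1.5-fold higher number from compound 2 to compound 3 (0.18 log units; within the scatter), so the two groups cannot be told apart at this position on the fluorinated core. With the 4-fluorophenyl side chain held fixed, adding the fluoro to the core gives a 2.9-fold lower number from compound 1 to compound 3 (0.47 log units; beyond the scatter), a modest step but one beyond the scatter, and this separates the two changes that could not be read apart in the earlier pair. No measurement in hand explains the size of either step.

Going by these compounds, only methyl and fluoro are seen at the side-chain position, so it remains open how a methoxy group, an amine or a carboxylic acid would read there. On these data alone, it is also open whether the step from the core fluoro carries over to the 4-methylphenyl side chain, and whether a chloro group on the same core carbon would read like fluoro.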